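The compounds below may be only part of what the source reports. "The series", "measured", "known", "first", "only" and "open" are said of these compounds alone.

In an ADME assay on L929 cells (Mus musculus) for cytotoxicity, read by resazurin assay, with a stated time of 96 h (on this read-out higher numbers stand for lower toxicity in this test and lower numbers for higher toxicity in this test), compound 1 (`NC(=S)N/N=C(/COc1ccc(Br)cc1)c1ccc(Br)cc1`) gives 22600 nM, while for compound 2 (`Fc1ccc(/C(COc2ccc(Br)cc2)=N\NC(=S)Nc2ccccc2)cc1`) the result is "not determined" (no result reported). Compound 3 (`CC(C)c1ccc(OC/C(=N\NC(N)=S)c2ccc(Br)cc2)cc1`) gives 24600 nM, which lies within the scatter of the value for compound 1. Compound 4 (`NC(=S)N/N=C(\COc1ccc(Cl)cc1)c1ccc(Br)cc1`) carries chloro in place of isopropyl on an aromatic carbon. Going by the values given here, no step between measured compounds that differ in one place is available, so the expectation rests on compound 3 at 24600 nM and compound 1 at 22600 nM. No change beyond the scatter is expected in this assay, in either direction. The expected step of a 1.1-fold lower number from compound 3 to compound 4 (0.03 log units; within the scatter) is therefore small. For compound 4 the estimated value is 23000 nM, with an expected range of 12000 nM to 45000 nM.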

Compound 4, half-maximal cytotoxic concentration: < 25100 nM
Compound 4: a limit, no number (the forecaster's own chance of this, stated with the estimate: 5%); the middle value lies beyond the limit too.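

Going by these compounds alone, compound 4 gives < 25100 nM, a limit and not a number, so no step from compound 3 to compound 4 can be read. The compounds shown leave open whether chloro in place of isopropyl changes the result in this assay at all.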